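A few compounds are considered here, and "the series" means these few. Any claim that something is new, unique, unknown or untested is made for them only; others in the source may bear on it.

Compound 1 `CC(=O)N(C)CC#CCn1ccnc1`: 0.97 mg/kg
Compound 2 `COC(=O)N(C)CC#CCN1CCCC1`: 1.4 mg/kg

Within the data shown here, both compounds have been measured in a functional assay on the whole organism for agonist activity, with Mus musculus as the target; on this read-out higher numbers stand for an effect only at larger amounts of compound and lower numbers for an effect already at smaller amounts. In this assay compound 2 gives 1.4 mg/kg and compound 1 gives 0.97 mg/kg, so the two values lie within the usual scatter of each other.

The next compound to consider is compound 3 `COC(=O)N(C)CC#CCn1ccnc1`. It differs from compound 2 in one place, a saturated chain carbon bound to a triple-bonded carbon: 1H-imidazol-1-yl in place of pyrrolidin-1-yl on a saturated chain carbon bound to a triple-bonded carbon. Among the measured compounds shown here, no pair of measured compounds shows this exchange on its own, so its effect cannot be read directly from the data. For the measured compounds named here, the only hint is compound 1, which also carries 1H-imidazol-1-yl and gives 0.97 mg/kg. With so little evidence, no step beyond the scatter is expected in this assay, in either direction, and the uncertainty stays wide. The expected change is a 1.1-fold higher number from compound 2 to compound 3 (0.03 log units; within the scatter). For compound 3 the estimated value is 1.5 mg/kg, with an expected range from 0.4 mg/kg to 5.5 mg/kg.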

Compound 3, dose for half-maximal effect: 2 mg/kg
Beside the measured number, compound 3's estimate is 1.3-fold (0.12 log units) below it; the range from low to high includes it.
By their numbers in this assay, from the lowest: compounds 1, 2 and 3 (each within the scatter of the next, the first and the last beyond it).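

In this assay, the exchange of pyrrolidin-1-yl for 1H-imidazol-1-yl on a saturated chain carbon bound to a triple-bonded carbon can now be read on its own, with methoxy on the carbonyl carbon held constant, and it gives a 1.4-fold higher number from compound 2 to compound 3 (0.15 log units; within the scatter). So at this position, the non-aromatic ring and the aromatic ring with its additional ring nitrogen cannot be told apart in this read-out. With 1H-imidazol-1-yl held constant, methoxy in place of methyl on a carbonyl carbon gives a 2.1-fold higher number from compound 1 to compound 3 (0.31 log units; beyond the scatter), a modest step and the only one here beyond the scatter, while no measurement at hand accounts for either step.

It remains open whether the step at the carbonyl carbon would also appear with pyrrolidin-1-yl on the chain carbon, since the compounds shown pair methyl on the carbonyl carbon only with 1H-imidazol-1-yl. Also open, on these data alone, is how ethoxy on the carbonyl carbon, or a dimethylamino group on the saturated chain carbon, would read in this assay.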